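Replacing the Dichloropyridinyl Group of Compound 2

This account rests on a few compounds, and the source may have more. Where it says the series, first, only, none or still open, it means among the compounds named here.

In a functional assay on SW620/5-FU cells (Homo sapiens) for cytotoxicity, read by MTT assay, with a stated time of 48 h, in the presence of a further agent that is not named here (a higher number here means that more compound is needed for the effect, a lower number that less compound is needed), compound 1 (`COc1cc(NC(=O)NNc2cc(-c3ccc(F)cc3)c3cnn(C)c3n2)cc(Cl)n1`) gives 24100 nM and compound 2 (`Cn1ncc2c(-c3ccc(F)cc3)cc(NNC(=O)Nc3cc(Cl)nc(Cl)c3)nc21`) gives 9150 nM, the lower of the two numbers. The next analogue, compound 3 (`Cn1ncc2c(-c3ccc(F)cc3)cc(NNC(=O)Nc3cc(F)cc(F)c3)nc21`), differs from compound 2 at a single place: 3,5-difluorophenyl in place of 2,6-dichloropyridin-4-yl on an amide-type nitrogen. In words, 3,5-difluorophenyl stands in place of 2,6-dichloropyridin-4-yl on an amide-type nitrogen. Going by the values given here, only one measured step bears on this change, and it is modest: a 2.6-fold lower number from compound 1 to compound 2 (0.42 log units; beyond the scatter), with chloro in place of methoxy on an aromatic carbon. Among the compounds with values here, that step altered the ring that leaves here, but no measured compound carries a ring of carbon only at this place. A shift no larger than that modest step is therefore expected, and its direction remains uncertain. The expected change is a 1.2-fold higher number from compound 2 to compound 3 (0.08 log units; within the scatter). For compound 3 the estimate is 11000 nM, with an expected range of 3500 nM to 32000 nM.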

Compound 3, half-maximal effective concentration: 47400 nM
Compound 3: middle estimate off by 4.3-fold (0.63 log units), on the low side; the measured number lies above the stated range.
By their numbers in this assay, from the lowest: compound 2; then compounds 1 and 3 (each within the scatter of the next).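

In this assay, putting a ring of carbon only on the amide-type nitrogen gives a 5.2-fold higher number from compound 2 to compound 3 (0.71 log units; beyond the scatter) and so shows a rise in the number, a direction that the earlier step did not show at this place. Measured against the 2-chloro-6-methoxypyridin-4-yl group, the 3,5-difluorophenyl group gives a 2.0-fold higher number from compound 1 to compound 3 (0.29 log units; within the scatter) and so does not separate compound 3 from compound 1. Nothing measured on hand accounts for this result.

Compound 2 and compound 3 differ in both the ring nitrogen and the halogens, so the compounds shown leave open which of the two carries the step; a 3,5-dichlorophenyl group at this place would separate them. Also open, from the compounds shown here alone, is how an amine or a carboxylic acid on this ring would read in this assay.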